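The source may report more compounds than this note shows. Statements on the series, on what has been measured and on what is new or still open speak of the compounds shown alone.

In an in vitro ADME assay on microsomes from liver (Homo sapiens) for metabolic stability (on this read-out lower numbers stand for slow clearance and higher numbers for fast clearance), the measured compounds read as follows.
Compound 1 `COc1ccc(C(=O)N2CCC(=CC(=O)N[C@@H]3CCN(Cc4ccc5cc(F)ccc5c4)C3)CC2)cc1` gives 252 mL/min/kg
Compound 2 `COc1cccc(C(=O)N2CCC(=CC(=O)N[C@@H]3CCN(Cc4ccc5cc(F)ccc5c4)C3)CC2)c1` gives 500 mL/min/kg
Compound 3 `COc1ccc(C(=O)N2CCC(=CC(=O)N[C@@H]3CCN(Cc4ccc5cc(F)ccc5c4)C3)CC2)c(O)c1` gives 232 mL/min/kg

Compound 2 lies within the scatter of one neighbour (a 2.0-fold higher number from compound 1 to compound 2 (0.30 log units; within the scatter)) but not of the other (a 2.2-fold lower number from compound 2 to compound 3 (0.33 log units; beyond the scatter)). Compound 4 `O=C(C=C1CCN(C(=O)c2cccc(F)c2)CC1)N[C@@H]1CCN(Cc2ccc3cc(F)ccc3c2)C1` carries fluoro in place of methoxy on an aromatic carbon, meta to a large group (fluoro in place of methoxy on an aromatic carbon). For the measured compounds named here, no measured step makes this exchange, so those two steps, together with the small one of (a 1.1-fold lower number from compound 1 to compound 3 (0.04 log units; within the scatter)), are the only guide, and all are modest at most. A similarly small, downward move is expected, with the estimated step (a 1.7-fold lower number from compound 2 to compound 4 (0.22 log units; within the scatter)) staying within the scatter. For compound 4 the estimate is 300 mL/min/kg in an expected range of 150 mL/min/kg to 600 mL/min/kg in this assay terms.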

Compound 4, clearance: 459 mL/min/kg
Compound 4: the middle estimate sits 1.5-fold (0.18 log units) below what was measured; measured number inside the range.
By their numbers in this assay, from the lowest: compounds 3, 1, 4 and 2 (each within the scatter of the next, the first and the last beyond it).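

In this assay, fluoro in place of methoxy on this aromatic carbon, meta to a large group, leaves the number within the scatter (a 1.1-fold lower number from compound 2 to compound 4 (0.04 log units; within the scatter)), so this exchange does not separate the two compounds. The steps to the other compounds (a 2.0-fold higher number from compound 3 to compound 4 (0.30 log units; within the scatter); a 1.8-fold higher number from compound 1 to compound 4 (0.26 log units; within the scatter)) also stay within the scatter, so compound 4 cannot be told apart from any earlier compound, even though compound 2 and compound 3 differ beyond it. Nothing available offers a reason for this result. Going by these compounds, whether an amine or a carboxylic acid on this carbon would give a step beyond the scatter remains open. So does whether fluoro in place of the methoxy of compound 1 would read the same way.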